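The compounds below may be only part of what the source reports. "The series", "measured", "known", "first", "only" and "open" are said of these compounds alone.

In a functional assay on HEY cells (Homo sapiens) for cytotoxicity, read by MTT assay, with a stated time of 72 h (on this read-out lower numbers stand for stronger inhibition and higher numbers for weaker inhibition), compound 1 (`COc1cccc(CNC(=O)c2nc(Br)c3cccnc3c2N[C@H]2CC[C@H](N)CC2)c1`) gives 7000 nM and compound 2 (`COc1ccc(CNC(=O)c2nc(Br)c3cccnc3c2N[C@H]2CC[C@H](N)CC2)cc1`) gives 4000 nM so the two measured compounds lie within the scatter of each other. Compound 3 (`CN(C)c1ccc(CNC(=O)c2nc(Br)c3cccnc3c2N[C@H]2CC[C@H](N)CC2)cc1`) has not yet been measured. It differs from compound 1 in one group (4-(dimethylamino)phenyl in place of 3-methoxyphenyl on a saturated chain carbon bound to an amide-type nitrogen), with 4-(dimethylamino)phenyl in place of 3-methoxyphenyl on a saturated chain carbon bound to an amide-type nitrogen. Among the compounds with values here, the only measured step that bears on this change is a 1.8-fold lower number from compound 1 to compound 2 (0.24 log units; within the scatter) with 4-methoxyphenyl in place of 3-methoxyphenyl at that same place. That single step gives no ground to expect a shift beyond the scatter in this assay in either direction. The estimate therefore means a 1.6-fold lower number from compound 1 to compound 3 (0.19 log units; within the scatter) as the expected step. For compound 3 the expected value is 4500 nM with an estimated range from 1500 nM to 12000 nM on this limited evidence.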

Compound 3, half-maximal inhibitory concentration: 5300 nM
Compound 3: middle estimate off by 1.2-fold (0.07 log units), on the low side; the measured number falls inside the stated range.
By their numbers in this assay, from the lowest: compounds 2, 3 and 1 (each within the scatter of the next).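

In this assay, within the data shown here, 4-(dimethylamino)phenyl in place of 3-methoxyphenyl gives a 1.3-fold lower number from compound 1 to compound 3 (0.12 log units; within the scatter), while dimethylamino in place of methoxy on an aromatic carbon gives a 1.3-fold higher number from compound 2 to compound 3 (0.12 log units; within the scatter) and so changes only that one group. Until now this place had been probed only by moving a methoxy group, and these steps add a group that carries nitrogen instead of oxygen, again with no shift beyond the scatter. All three compounds therefore lie within the scatter of their neighbours, and no order can be read among them.

Going by these compounds, whether a carboxylic acid or a primary amine on the phenyl ring, or a longer chain in place of the saturated chain carbon, would move the number beyond the scatter remains open. Nothing given here accounts for how closely these numbers agree.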